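Lipophilicity notes: from compound 3 to compound 4

This account rests on a few compounds, and the source may have more. Where it says the series, first, only, none or still open, it means among the compounds named here.

In a physicochemical assay for lipophilicity, read by HPLC, at pH 7.4 (a lower number here means a more polar compound, a higher number a more lipophilic compound), compound 3 `CCOC(=O)COc1ccc([C@H]2CC[C@]3(CC2)OOC2(O3)C3CC4CC(C3)CC2C4)cc1` gives > 5.3. That reading is a limit of the assay and not a number.

In this assay compound 1 `O=C(O)COc1ccc([C@H]2CC[C@]3(CC2)OOC2(O3)C3CC4CC2CC(C3)C4O)cc1` gives 1.7, and compound 2 `O=C(O)c1cccc([C@H]2CC[C@]3(CC2)OOC2(O3)C3CC4CC(C3)CC2C4)c1` gives 3. Both carry a free carboxy group, which compound 3 lacks, and both return numbers.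

The change to compound 4 `CC(C)(Oc1ccc([C@H]2CC[C@]3(CC2)OOC2(O3)C3CC4CC(C3)CC2C4)cc1)C(=O)O` is 1-carboxy-1-methylethyl in place of (ethoxycarbonyl)methyl on an oxygen on an aromatic ring. Among the compounds with values here, no measured pair isolates this change, so the expectation rests on the compounds with a carboxy group. Since it shares the core of compound 3, whereas the core of compound 1 also holds a hydroxyl, the closer guide is compound 2, which gives 3.

A large downward move is therefore expected, estimated as a number at least 2.30 log units lower from compound 3 to compound 4 (beyond the scatter).

For compound 4 the expected value is 3, within an estimated range of 2.3 to 3.6.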

Compound 4, distribution coefficient: 3.1
For compound 4 the middle estimate is 0.10 log units below the measured one; the measured number falls inside the stated range.
By their numbers in this assay, from the lowest: compound 1; then compounds 2 and 4 (each within the scatter of the next). At a limit, above all of these: compound 3.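

In this assay, within the data shown here, the first pair of the series that differs in one place shows a number at least 2.20 log units lower from compound 3 to compound 4 (beyond the scatter). That step has a floor and no upper end, since the reading for compound 3 is a limit of the assay and not a number: the limit of > 5.3 in this assay, at which 1 of the 4 values shown sits. With the shared core held constant, replacing (ethoxycarbonyl)methyl with 1-carboxy-1-methylethyl on that oxygen gives compound 4, which returns a number in this assay.

The step changes the ethyl ester and the branching of the chain together, and the compounds shown do not separate the two. From the compounds shown here alone, how an amine, a primary amide or a longer chain ending in a carboxylic acid would read on that oxygen remains open.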